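The compounds below may be only part of what the source reports. "The series", "measured", "known", "first", "only" and "open" are said of these compounds alone.

In a functional assay on A2780 cells (Homo sapiens) for antiproliferative activity, read by CellTiter-Glo, with a stated time of 4 days (on this read-out lower numbers stand for stronger inhibition and higher numbers for weaker inhibition), compound 1 (`O=C(NCc1cccnc1)Nc1ccc(CNC(=O)c2ccc(CN3CCNCC3)cc2)cc1`) gives 8 nM and compound 3 (`CCC(=O)N[C@@H](C)c1ccc(NC(=O)[C@H]2C[C@@H]2c2cccnc2)cc1`) gives 5 nM so these two lie within the usual scatter of each other. For the measured compounds named here, compound 2 (`CCC(=O)NCc1ccc(NC(=O)[C@H]2C[C@@H]2c2cccnc2)cc1`) gives a much higher 405 nM in this assay and so compound 3 sits with compound 1 at the low end of the numbers so far.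

Going by the values given here, the one measured step between close relatives is an 81-fold lower number from compound 2 to compound 3 (1.91 log units; beyond the scatter) and it comes from methyl in place of hydrogen on a saturated chain carbon. Compound 4 (`C[C@H](NC(=O)c1ccc(F)cc1)c1ccc(NC(=O)[C@H]2C[C@@H]2c2cccnc2)cc1`) changes a different place: 4-fluorophenyl in place of ethyl on a carbonyl carbon with 4-fluorophenyl in place of ethyl on a carbonyl carbon.

Among the compounds with values here, the large measured step therefore says little about this change, and no measured pair varies the group on this carbonyl carbon. The only further hint is that compound 1, whose remaining structure differs, has an aromatic ring on an amide carbonyl and still gives 8 nM in this assay as a low number. On this thin evidence, no step beyond the scatter is expected in this assay in either direction, though the uncertainty is wide. The estimate means a 1.2-fold higher number from compound 3 to compound 4 (0.08 log units; within the scatter) as the expected step. For compound 4 the estimated value is 6 nM within an expected range of 1.5 nM to 25 nM for the coming measurement.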

Compound 4, half-maximal inhibitory concentration: 2 nM
The estimate for compound 4 lay 3.0-fold (0.48 log units) above the measured number; measured number inside the range.
By their numbers in this assay, from the lowest: compound 4; then compounds 3 and 1 (each within the scatter of the next); then compound 2.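

In this assay, for the compounds shown here, this is the first measured change on this carbonyl carbon, and it gives a 2.5-fold lower number from compound 3 to compound 4 (0.40 log units; beyond the scatter). The step is modest but beyond the scatter, and it shows that the low number of compound 3 does not depend on keeping ethyl here: a ring-bearing group, 4-fluorophenyl, with more heavy atoms than ethyl, is accepted on this carbon and gives a still lower number in this assay. No measurement shown accounts for this drop, so the step records what happens at this position and not why it happens.

Going by these compounds, with only ethyl and 4-fluorophenyl compared on this carbon, it remains open whether the lower number belongs to the ring or to its fluorine, which a plain phenyl ring would test, and whether a longer chain such as butyl, or a group carrying an amine or a carboxylic acid, would be accepted as well. On these data alone, it is also open whether the large effect of the methyl on the saturated chain carbon, seen with ethyl on the carbonyl, would hold with 4-fluorophenyl in that place.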